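A few compounds are considered here, and "the series" means these few. Any claim that something is new, unique, unknown or untested is made for them only; others in the source may bear on it.

Measured so far:
compound 1, `CCN(Cc1cccnc1)c1ccc(C(=O)N2CCc3ccc(OS(N)(=O)=O)cc3C2)cc1`, in a physicochemical assay for lipophilicity (a lower number here means a more polar compound, a higher number a more lipophilic compound), gives 1.93;
compound 2, `CCN(Cc1ccccc1)c1ccc(C(=O)N2CCc3ccc(OS(N)(=O)=O)cc3C2)cc1`, in this assay gives 3.08.

Compound 2 stands highest of the two numbers. Its nearest neighbour is compound 1, and the step of a number 1.15 log units higher from compound 1 to compound 2 (beyond the scatter) lies beyond the scatter and is large.

Compound 3, `CN(C)CCN(Cc1ccccc1)c1ccc(C(=O)N2CCc3ccc(OS(N)(=O)=O)cc3C2)cc1`, has not yet been measured in this assay. It differs from compound 2 as follows: dimethylamino in place of hydrogen on a saturated chain carbon, two bonds along the chain from a nitrogen on an aromatic ring. Among the measured compounds shown here, no measured step covers this change. For the measured compounds named here, the one step known, a number 1.15 log units higher from compound 1 to compound 2 (beyond the scatter), concerns phenyl in place of pyridin-3-yl at a different place and cannot be carried over to a dimethylamino entering for hydrogen. The expectation therefore rests on the structural change alone and is held loosely: the estimated step is a number 1.18 log units lower from compound 2 to compound 3 (beyond the scatter), a drop rather than a rise, with a wide range. For compound 3 the value in this assay is estimated at 1.9, expected to fall between 1 and 2.8.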

Compound 3, partition coefficient: 1.93
For compound 3 the middle estimate is 0.03 log units below the measured one; low and high end bracket the measured number.
By their numbers in this assay, from the lowest: compounds 1 and 3 (each within the scatter of the next); then compound 2.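

In this assay, dimethylamino in place of hydrogen on a saturated chain carbon, two bonds along the chain from a nitrogen on an aromatic ring, gives a number 1.15 log units lower from compound 2 to compound 3 (beyond the scatter), a large step. The earlier pair showed a change only at the phenyl and pyridin-3-yl group; this result shows that the number also responds to a change at ethyl, here ethyl to 2-(dimethylamino)ethyl, with phenyl kept. Nothing available here accounts for the size of this step.

Going by these compounds, whether a hydroxyl group, a morpholine or a longer chain carrying dimethylamino would give a step of similar size at this place remains open. Also open, on these data alone, is what 2-(dimethylamino)ethyl would do in a compound that keeps pyridin-3-yl in place of phenyl.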